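The source may report more compounds than this note shows. Statements on the series, on what has been measured and on what is new or still open speak of the compounds shown alone.

Compound 1 `CC(C)N(Cc1cccc(OCCCCCC(=O)O)c1)C(=O)c1ccc(-c2cccc(N(C)C)c2)cc1`: > 26000 nM
Compound 2 `CC(C)N(Cc1cccc(OCCCCCC(=O)O)c1)C(=O)c1ccc(-c2cccc(Oc3ccccc3)c2)cc1`: > 18700 nM
Compound 3 `CCOC(=O)CCCCCOc1cccc(CN(C(=O)c2ccc(-c3cccc(N(C)C)c3)cc2)C(C)C)c1`: > 26000 nM

In an ADME assay on BJ cells (Homo sapiens) for cytotoxicity, read by CellTiter-Glo and resazurin assay, with a stated time of 72 h (a lower number here means that less compound is needed, a higher number that more compound is needed for the effect), none of the three measured compounds gave a number. Compound 1 stopped at a limit of the assay, > 26000 nM. Compound 2 likewise stopped at a limit, > 18700 nM. Compound 3 also gave only a limit, > 26000 nM, and so stands at the limit of > 26000 nM in this assay, at which 2 of the 3 values shown sit. The change from compound 1 to compound 2, phenoxy in place of dimethylamino on an aromatic carbon, gave a step that the two limits leave unreadable from compound 1 to compound 2; the change from compound 1 to compound 3, ethyl in place of hydrogen on an oxygen next to a carbonyl group, gave a step that the two limits leave unreadable from compound 1 to compound 3. Compound 4 `CCOC(=O)CCCCCOc1cccc(CN(C(=O)c2ccc(-c3ccoc3)cc2)C(C)C)c1` has not yet been measured in this assay. It differs from compound 3 by furan-3-yl in place of 3-(dimethylamino)phenyl on an aromatic carbon. Neither measured step touches this change, and both are unreadable in size, so no direction can be taken from them; all three values sit at limits, two at the limit of > 26000 nM in this assay, at which 2 of the 3 values shown sit, and one at the limit of > 18700 nM in this assay, at which 1 of the 3 values shown sits. Compound 4 is therefore expected to show a step that the limit leaves unreadable from compound 3 to compound 4, nothing beyond the scatter. The estimate for compound 4 is 40000 nM, within 15000 nM to 120000 nM, most likely reported once more only as a limit.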

Compound 4, half-maximal effective concentration: > 26000 nM
Compound 4: no number, only a limit; the forecaster's own chance of this, stated with the estimate: 80%; the middle value does not contradict the limit.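

Compound 3 and compound 4 each gave only a limit, so the step from one to the other cannot be read: the limit of > 26000 nM in this assay, at which 3 of the 4 values shown sit.

The compounds shown leave open at what concentration, if any, each of them would reach a half-maximal effect in this assay.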